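Ring substituent swap at the benzothiazole end of the chain

The source may hold more compounds than are shown below. What is called first, only, known or untested is meant among the compounds shown, and "the series" means these compounds.

Measured so far in an ADME assay on MDCK cells (Canis lupus familiaris) for cytotoxicity, read by sulforhodamine B assay, with a stated time of 48 h; a higher number here means a weaker inhibitor, a lower number a stronger inhibitor:
compound 1 `O=c1cc(-c2ccccc2)oc2cc(OCCCCNc3nc4ccccc4s3)cc(O)c12` gives 348 ug/mL;
compound 2 `Cc1ccc2nc(NCCCCOc3cc(O)c4c(=O)cc(-c5ccccc5)oc4c3)sc2c1` gives 294 ug/mL;
compound 3 `O=c1cc(-c2ccccc2)oc2cc(OCCCCNc3nc4ccc([N+](=O)[O-])cc4s3)cc(O)c12` gives 310 ug/mL.

Compound 2 sits within the scatter of both neighbours: a 1.2-fold lower number from compound 1 to compound 2 (0.07 log units; within the scatter) and a 1.1-fold higher number from compound 2 to compound 3 (0.02 log units; within the scatter), so the three numbers cannot be told apart. Compound 4 `O=c1cc(-c2ccccc2)oc2cc(OCCCCNc3nc4ccc(Br)cc4s3)cc(O)c12` differs from compound 2 by bromo in place of methyl on an aromatic carbon, on the aromatic carbon that carries methyl in compound 2, hydrogen in compound 1 and nitro in compound 3. Within the data shown here, the steps that bear on this change were both small, and a 1.1-fold lower number from compound 1 to compound 3 (0.05 log units; within the scatter) likewise. A step no larger than the scatter, in no particular direction, is therefore expected: a 1.0-fold higher number from compound 2 to compound 4 (0.01 log units; within the scatter). Compound 4 is expected to give 300 ug/mL, with a range from 200 ug/mL to 450 ug/mL.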

Compound 4, half-maximal inhibitory concentration: 289 ug/mL
Beside the measured number, compound 4's estimate is 1.0-fold (0.02 log units) above it, within the range that was stated.
By their numbers in this assay, from the lowest: compounds 4, 2, 3 and 1 (each within the scatter of the next).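

At the aromatic carbon that carries bromo in compound 4, a halogen now joins hydrogen, methyl and nitro, and this assay still separates none of them (a 1.0-fold lower number from compound 2 to compound 4 (0.01 log units; within the scatter); a 1.1-fold lower number from compound 3 to compound 4 (0.03 log units; within the scatter); a 1.2-fold lower number from compound 1 to compound 4 (0.08 log units; within the scatter)). Across these four compounds, the substituent at this position leaves the number within the scatter. No available evidence accounts for this flat reading.

Going by these compounds, whether an amine or a carboxylic acid on this carbon would produce a step beyond the scatter remains open. So does the outcome of a longer chain joining the 1,3-benzothiazol-2-yl amino end to the shared core.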